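This account rests on a few compounds, and the source may have more. Where it says the series, first, only, none or still open, it means among the compounds named here.

Three compounds sharing one core were tested in a functional assay on NCI-H522 cells (Homo sapiens) for inhibition, read by sulforhodamine B assay, with a stated time of 48 h, tested at 10 uM; on this read-out lower numbers stand for less inhibition and higher numbers for more inhibition at the one concentration tested (going by the name of the read-out). Compound 1 `c1ccc2c(-c3cn4ccnc4c(-c4ccc5ncn(C6CCCCC6)c5c4)n3)cccc2c1` gives 19.3%, compound 2 `c1cn2cc(-c3ccsc3)nc(-c3ccc4ncn(C5CCCCC5)c4c3)c2n1` gives 10.3%, and compound 3 `Brc1ccc(-c2cn3ccnc3c(-c3ccc4ncn(C5CCCCC5)c4c3)n2)cc1` gives 35.5%. Compound 2 and compound 1 are separated only by a gap within the scatter, a number 9 percentage points lower from compound 1 to compound 2 (within the scatter), so the two cannot be ranked against each other, whereas the step of a number 25.2 percentage points higher from compound 2 to compound 3 (beyond the scatter) is real, if modest.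

Compound 4 `FC(F)(F)c1cccc(-c2cn3ccnc3c(-c3ccc4ncn(C5CCCCC5)c4c3)n2)c1` has not yet been measured. It differs from compound 2 by a single swap: 3-(trifluoromethyl)phenyl in place of thiophen-3-yl on an aromatic carbon. Of the measured steps, the one that bears most directly is a number 25.2 percentage points higher from compound 2 to compound 3 (beyond the scatter), where the same thiophen-3-yl gave way to a six-membered aromatic ring of carbon only carrying one group, and the step of a number 16.2 percentage points higher from compound 1 to compound 3 (beyond the scatter) points the same way. Both were modest rises; the swap in compound 4 likewise puts a six-membered aromatic ring of carbon only in place of the thiophen-3-yl, so a modest rise beyond the scatter is expected in this assay. Compound 4 is therefore estimated at 28%, with a range from 12% to 45%. That estimate amounts to an expected step of a number 17.7 percentage points higher from compound 2 to compound 4 (beyond the scatter).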

Compound 4, a percentage reported as inhibition, at one concentration (the size of the read-out at that concentration, not a potency): 10.7%
The estimate for compound 4 lay 17.3 percentage points above the measured number; measured number below the stated range.
By their numbers in this assay, from the lowest: compounds 2, 4 and 1 (each within the scatter of the next); then compound 3.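

In this assay a six-membered aromatic ring of carbon only at this position does not by itself raise the number: the steps of a number 0.4 percentage points higher from compound 2 to compound 4 (within the scatter) and a number 8.6 percentage points lower from compound 1 to compound 4 (within the scatter) leave compound 4 indistinguishable from both compound 2 and compound 1. The step of a number 24.8 percentage points lower from compound 3 to compound 4 (beyond the scatter) shows instead that the two substituted phenyl groups are not interchangeable, so the higher number of compound 3 goes with 4-bromophenyl rather than with any such ring. Nothing available explains this difference between the two groups.

Since 4-bromophenyl and 3-(trifluoromethyl)phenyl differ in both the substituent and its place on the ring, the compounds shown cannot separate those two changes. Nor do they show how an unsubstituted phenyl, 3-bromophenyl, 4-(trifluoromethyl)phenyl or a ring carrying an amine would read.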